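Swapping a Chloro for an Amino Group: Expected Cytotoxicity

This account rests on a few compounds, and the source may have more. Where it says the series, first, only, none or still open, it means among the compounds named here.

Two measured compounds share a core that carries a benzyl group bearing a chloromethyl substituent. Compound 1 `ClCc1ccccc1Cn1cnc2c(Cl)nc(Cl)nc21` and compound 2 `ClCc1ccccc1Cn1cnc2ncnc(Cl)c21` were tested in a functional assay on MOLT-4 cells (Homo sapiens) for cytotoxicity, read by sulforhodamine B assay, with a stated time of 48 h; a lower number here means that less compound is tolerated, a higher number that more compound is tolerated. Compound 1 gives 3540 nM, the lowest of the two numbers, while compound 2 gives 16600 nM, a higher number beyond the usual scatter. Compound 3 `Nc1nc(Cl)c2ncn(Cc3ccccc3CCl)c2n1` has not been measured. It differs from compound 1 in one place: amino in place of chloro on an aromatic carbon. Within the data shown here, no pair of measured compounds isolates this exact change, so the expectation rests on the two numbers alone. Compound 2, which lacks that chloro altogether, gives 16600 nM, so removing or replacing it seems to allow more compound to be tolerated. A smaller shift in the same direction is expected here, amounting to a 2.3-fold higher number from compound 1 to compound 3 (0.35 log units; beyond the scatter). Compound 3 is therefore estimated at 8000 nM, with a likely range from 2500 nM to 25000 nM.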

Compound 3, concentration lethal to 50% of the cells: > 100000 nM
Compound 3 ended at the assay's limit (the forecaster's own chance of this, stated with the estimate: 5%); middle value at least 12-fold (1.09 log units) from the limit.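

In this assay, among these compounds, this single-atom exchange on the aromatic carbon between two ring nitrogen atoms gives an at least 28-fold higher number from compound 1 to compound 3 (1.45 log units; beyond the scatter), the first step in this set that isolates one change. Amino in place of chloro brings in a hydrogen-bond donor and a hydrogen-bond acceptor, and the data show that this position strongly affects the read-out, although they do not show which feature of the exchange is responsible. On these data alone, the value for compound 3 is a limit of the assay and not a number, so the full size of the step stays unknown: the limit of > 100000 nM in this assay, at which 1 of the 3 values shown sits.

As far as these compounds go, it remains open whether amino is unusual here or whether other replacements for chloro, such as a methoxy or a methylamino group, would give a similar result. The compounds shown also leave open how much the other chloro group contributes.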